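Working notes: compound 3 to compound 4

The source may report more compounds than this note shows. Statements on the series, on what has been measured and on what is new or still open speak of the compounds shown alone.

Three members of the series have been run in a functional assay on MCF7 cells (Homo sapiens) for antiproliferative activity, read by MTT assay, with a stated time of 48 h; on this read-out lower numbers stand for stronger inhibition and higher numbers for weaker inhibition. Compound 1 `CCOc1ccc(-n2nncc2CN2C(=O)C3(C(C#N)=C(N)Oc4c3c3nc5ccccc5nc3c3ccccc43)c3ccccc32)cc1` gives > 50000 nM in this assay, which is a limit of the assay and not a number. Compound 2 `N#CC1=C(N)Oc2c(c3nc4ccccc4nc3c3ccccc23)C12C(=O)N(Cc1cnnn1-c1ccc([N+](=O)[O-])cc1)c1ccccc12` gives > 50000 nM in this assay, again a limit. Going by the values given here, the one measured step so far, a step that the two limits leave unreadable from compound 1 to compound 2, is nitro in place of ethoxy on an aromatic carbon and lies between two limits. Compound 3 `N#CC1=C(N)Oc2c(N)cc3nc4ccccc4nc3c2C12C(=O)N(Cc1cnnn1-c1ccc(F)cc1)c1ccccc12`, the parent of the present step, gives > 50000 nM in this assay, also a limit. Compound 3 thus stands where the whole set stands, at the limit of > 50000 nM in this assay, at which 3 of the 3 values shown sit.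

Compound 4 `N#CC1=C(N)Oc2c(N)cc3nc4ccccc4nc3c2C12C(=O)N(Cc1cnnn1-c1cc(Cl)ccc1Cl)c1ccccc12` is the untested member. Its difference from compound 3 is 2,5-dichlorophenyl in place of 4-fluorophenyl on an aromatic nitrogen. Among the compounds with values here, no measured step concerns this change; the only measured step, a step that the two limits leave unreadable from compound 1 to compound 2, is unreadable, and every value obtained so far sits at the limit. No movement beyond the scatter is expected in this assay, so the step from compound 3 to compound 4 is estimated as a step that the limit leaves unreadable from compound 3 to compound 4. Compound 4 is accordingly expected to give 60000 nM in this assay, within 20000 nM to 200000 nM, most likely reported once more only as a limit.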

Compound 4, half-maximal inhibitory concentration: 33200 nM
Beside the measured number, compound 4's estimate is 1.8-fold (0.26 log units) above it, and the stated range covers the measured number.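

In this assay, going by these compounds alone, compound 4 gives 33200 nM, the only value in the set that is a number and not a limit of the assay. This change on the aromatic nitrogen is therefore the only one shown that is tied to a readable value, and it comes as an at least 1.5-fold lower number from compound 3 to compound 4 (0.17 log units; that floor lies within the scatter), so only a floor of the step is known and that floor does not establish a real gain. The number stands alone in a set otherwise held at a limit: the limit of > 50000 nM in this assay, at which 3 of the 4 values shown sit.

From the compounds shown here alone, the true size of the step stays open, as does which of the two chlorines matters. Also open, going by these compounds, is whether a phenyl bearing a single chlorine, a methoxy or an amine at this place gives a number in this assay.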